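The compounds below may be only part of what the source reports. "The series", "measured", "known", "first", "only" and "open" are said of these compounds alone.

Measured in an ADME assay on the whole organism (strain 129/SvEvBrd x C57BL/6) for metabolic stability, with Mus musculus as the target; a higher number here means that the compound lasts longer, a lower number that the compound disappears faster:
- compound 1 `CN(C)C(=O)c1nc([C@@H](O)[C@H](O)[C@H](O)CO)c[nH]1`: 4 h
- compound 2 `OC[C@@H](O)[C@@H](O)[C@H](O)c1c[nH]c(-c2cocn2)n1`: 1.2 h
- compound 3 `OC[C@@H](O)[C@@H](O)[C@H](O)c1c[nH]c(-c2ncc[nH]2)n1`: 3.2 h

Compound 3, at 3.2 h, is level with compound 1 within the scatter, and only compound 2 lies clearly lower. Compound 4 `Cn1cnc(-c2nc([C@@H](O)[C@H](O)[C@H](O)CO)c[nH]2)c1` is not yet measured. It carries 1-methyl-1H-imidazol-4-yl in place of 1H-imidazol-2-yl on an aromatic carbon. Three measured swaps of the group at this carbon bear on it: a 1.3-fold lower number from compound 1 to compound 3 (0.10 log units; within the scatter) stayed within the scatter, while a 3.3-fold lower number from compound 1 to compound 2 (0.52 log units; beyond the scatter) and a 2.7-fold higher number from compound 2 to compound 3 (0.43 log units; beyond the scatter) were modest. Both imidazolyl groups are close relatives, so no change beyond the scatter is expected, and the estimated step is a 1.3-fold lower number from compound 3 to compound 4 (0.11 log units; within the scatter). For compound 4 the expected half-life is 2.5 h, with an estimated range from 1.1 h to 5.5 h.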

Compound 4, half-life: 1.6 h
For compound 4 the middle estimate is 1.6-fold (0.19 log units) above the measured one, within the range that was stated.
By their numbers in this assay, from the lowest: compounds 2, 4, 3 and 1 (each within the scatter of the next, the first and the last beyond it).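

In this assay, the change to 1-methyl-1H-imidazol-4-yl gives a 2.0-fold lower number from compound 3 to compound 4 (0.30 log units; within the scatter) and, from the oxazole, a 1.3-fold higher number from compound 2 to compound 4 (0.12 log units; within the scatter), so compound 4 cannot be separated from either, although those two neighbours differ beyond the scatter. Only the dimethylcarbamoyl group stands clearly apart, with a 2.5-fold lower number from compound 1 to compound 4 (0.40 log units; beyond the scatter). Nothing measured here explains these steps.

The methyl group and the changed ring attachment arrive together, and an unmethylated 1H-imidazol-4-yl would separate them. An amine or a carboxylic acid on this carbon would test groups unlike these.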